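Replacing a dihydroxyphenyl carbonyl with a bromophenyl carbonyl

A few compounds are considered here, and "the series" means these few. Any claim that something is new, unique, unknown or untested is made for them only; others in the source may bear on it.

Compound 1 `Nc1c(Br)cc(Br)cc1/C=C(\C(=O)c1ccc(Br)cc1)S(=O)(=O)c1ccc(Br)cc1` gives 25000 nM.
Compound 2 `O=C(/C(=C\c1c(O)cc(O)cc1O)Sc1ccccc1Br)c1ccc(Br)cc1` gives > 100000 nM.
Compound 3 `O=C(/C(=C\c1ccc(O)c([N+](=O)[O-])c1)SCc1ccc(Br)cc1)c1ccc(O)cc1O` gives > 100000 nM.

These three values come from a functional assay on DU-145 cells (Homo sapiens) for inhibition, read by trypan blue exclusion, with a stated time of 96 h; on this read-out higher numbers stand for weaker inhibition of growth and lower numbers for stronger inhibition of growth. The value for compound 2 is a limit of the assay rather than a number. The value for compound 3 is likewise a limit, not a number, so compound 3 stands at the weak end of what is shown, and no number marks how weak. Compound 1 is the only one of the three with a measured number.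

Compound 4 `O=C(/C(=C\c1ccc(O)c([N+](=O)[O-])c1)SCc1ccc(Br)cc1)c1ccc(Br)cc1` has not yet been measured. It differs from compound 3 in one place: 4-bromophenyl in place of 2,4-dihydroxyphenyl on a carbonyl carbon. With this change compound 4 carries the same (4-bromophenyl)carbonyl that compound 1 carries, while keeping the rest of compound 3 unchanged. Among the measured compounds shown here, no step between measured compounds is given for this change, so its size can only be guessed. For the measured compounds named here, the only anchor is that compound 1, with that carbonyl, reaches a measured number while compound 3 does not. Compound 4 is therefore expected to move toward stronger inhibition of growth by an at least 2.0-fold lower number from compound 3 to compound 4 (0.30 log units; that floor lies within the scatter), though it may also stay at the limit. The estimate for compound 4 in this assay is 50000 nM, between 12000 nM and 200000 nM.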

Compound 4, concentration for 50% growth inhibition: 10000 nM
Compound 4: the middle estimate sits 5.0-fold (0.70 log units) above what was measured; measured number below the stated range.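

In this assay, putting 4-bromophenyl in place of 2,4-dihydroxyphenyl on a carbonyl carbon gives an at least 10-fold lower number from compound 3 to compound 4 (1.00 log units; beyond the scatter), so a change at this one place can shift growth inhibition beyond the scatter while the rest of compound 3 stays the same. Among the compounds shown here, this is the first comparison in the set that ties a difference to a single place, as the earlier compounds offered no such pair. The printed step is only a floor, and its full size remains unknown because compound 3 rests on a limit of the assay rather than on a number: the limit of > 100000 nM in this assay, at which 2 of the 4 values shown sit.

The change also combines two things, the loss of the hydroxyl groups and the arrival of bromine, and an unsubstituted phenyl on the same carbonyl carbon would be needed to separate them. A single pair also cannot show whether the swap would have a similar effect with other groups elsewhere on the molecule, or whether a chlorophenyl or an aminophenyl at this place would match the 4-bromophenyl.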